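From Compound 3 to Compound 4: a Larger Group Enters

The source may hold more compounds than are shown below. What is called first, only, known or untested is meant among the compounds shown, and "the series" means these compounds.

Compound 1 `CC(C)(C)c1ccc(Cn2cc(-c3cn([C@H]4C[C@H](O)[C@@H](CO)O4)c(=O)[nH]c3=O)nn2)cc1` gives 92.3% in a functional assay on PC-3 cells (Homo sapiens) for cytotoxicity, read by sulforhodamine B assay, tested at 10 uM; on this read-out lower numbers stand for less inhibition and higher numbers for more inhibition at the one concentration tested (going by the name of the read-out).
Compound 2 `CCCCCCCCc1cc(-c2cn([C@H]3C[C@H](O)[C@@H](CO)O3)c(=O)[nH]c2=O)on1` gives 77.3% in this assay.
Compound 3 `CC(=O)OC[C@H]1O[C@@H](n2cc(-c3cc(C)no3)c(=O)[nH]c2=O)C[C@@H]1OC(C)=O` gives 92.4% in this assay.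

Three compounds share a common core and have been run in this assay. Compound 3 carries the highest of the three numbers, but the gap to compound 1 lies within the usual scatter, so the two cannot be ranked against each other. Compound 2 sits clearly lower than compound 3, beyond the scatter.

Compound 4 `CC(=O)OC[C@H]1O[C@@H](n2cc(-c3cc(-c4ccc(C(C)(C)C)cc4)no3)c(=O)[nH]c2=O)C[C@@H]1OC(C)=O` has not yet been measured. It differs from compound 3 in one place: 4-(tert-butyl)phenyl in place of methyl on an aromatic carbon. The 4-(tert-butyl)phenyl group that enters here is the same group that compound 1 carries elsewhere in its structure, and compound 1 gives 92.3% in this assay.

Among the measured compounds shown here, no step between measured compounds isolates this change, so the expectation rests on the high number of compound 3 and the similar high number of compound 1. The step from compound 3 to compound 4 is expected to be small, a number 4.4 percentage points lower from compound 3 to compound 4 (within the scatter), and not beyond the scatter in either direction. Compound 4 is therefore estimated at 88%, within a range from 70% to 98%.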

Compound 4, a percentage reported as inhibition, at one concentration (the size of the read-out at that concentration, not a potency): 27.5%
Compound 4: the middle estimate sits 60.5 percentage points above what was measured, and the stated range ends above it.
By their numbers in this assay, from the lowest: compound 4; then compound 2; then compounds 1 and 3 (each within the scatter of the next).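

In this assay, among the compounds shown here, this position proves sensitive to what it carries: 4-(tert-butyl)phenyl in place of methyl on an aromatic carbon of the five-membered aromatic ring, next to the ring nitrogen, comes with a number 64.9 percentage points lower from compound 3 to compound 4 (beyond the scatter) and is the first step that isolates a single change. Compound 1 carries the same group elsewhere in its structure, so the high number of compound 1 cannot speak for this place, and a number seen with a group in one part of a structure cannot be carried over to another. Nothing measured explains the loss, and no information bears on its cause.

With a single step at this carbon, the compounds shown do not separate the contribution of the aromatic ring from that of the tert-butyl group, and a plain phenyl or a short chain such as ethyl in this place would begin to tell the two apart. From the compounds shown here alone, it also remains open whether the same step would look alike on a counterpart of compound 4 with free hydroxyl groups in place of the two acetates.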